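The compounds below may be only part of what the source reports. "The series", "measured", "known", "first", "only" and "open" are said of these compounds alone.

Series notes. Compound 1 `Cc1ccccc1OS(=O)(=O)c1ccc(NC(=O)NCCCCl)cc1` and compound 2 `CCc1ccccc1OS(=O)(=O)c1ccc(NC(=O)NCCCCl)cc1` share one core; compound 3 `CCNC(=O)Nc1cccc(S(=O)(=O)Oc2ccccc2C)c1` and compound 4 `CCNC(=O)Nc1cccc(S(=O)(=O)Oc2ccccc2CC)c1` share another. In a functional assay on M21 cells (Homo sapiens) for cytotoxicity, read by sulforhodamine B assay, with a stated time of 48 h (a higher number here means a weaker inhibitor, a lower number a stronger inhibitor), compound 1 gives 25000 nM. In the same assay, compound 2 gives 15000 nM. The change from compound 1 to compound 2 is methyl in place of hydrogen on a saturated chain carbon bound to an aromatic carbon and it produced a 1.7-fold lower number from compound 1 to compound 2 (0.22 log units; within the scatter), so the two numbers cannot be ordered. In this assay compound 3 gives 51000 nM, the highest of the three measured numbers, with its steps to compound 1 and to compound 2 both beyond the scatter. The difference between the core of compound 3 and the core of compound 1 is not broken down here.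

Compound 4 has not been measured. It differs from compound 3 by methyl in place of hydrogen on a saturated chain carbon bound to an aromatic carbon, the same change as that from compound 1 to compound 2, at the same place. Going by the values given here, the only guide is compound 1 and compound 2, where this change gave a 1.7-fold lower number from compound 1 to compound 2 (0.22 log units; within the scatter), a step within the scatter. For compound 4 a step of similar size and direction is therefore expected, a 1.6-fold lower number from compound 3 to compound 4 (0.20 log units; within the scatter). Since this rests on a single pair on a different core, the range is kept wide. The estimate for compound 4 in this assay is 32000 nM, from 15000 nM to 70000 nM.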

Compound 4, half-maximal inhibitory concentration: 30000 nM
For compound 4 the middle estimate is 1.1-fold (0.03 log units) above the measured one; low and high end bracket the measured number.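

In this assay the new pair reads a 1.7-fold lower number from compound 3 to compound 4 (0.23 log units; within the scatter), so compound 3 and compound 4 cannot be ordered on these numbers alone. Set beside the earlier pair, the change from 2-methylphenyl to 2-ethylphenyl reads alike on the two cores: the same change on two cores in this assay, a 1.7-fold lower number (0.22 log units; within the scatter) from compound 1 to compound 2 and a 1.7-fold lower number (0.23 log units; within the scatter) from compound 3 to compound 4, 1.0-fold (0.01 log units) apart, within the scatter of two such steps. This shows that the step carries from the core of compound 1 to the core of compound 3 with no detectable difference in size, but it does not show that the change has a real effect of its own: each step taken alone lies within the scatter, and agreement between two pairs on two cores says nothing about any further core or any other change.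

The compounds shown leave open whether a longer chain in place of the ethyl group, such as propyl or butyl, would move the number beyond the scatter on either core. Also open, on these data alone, is whether the two cores would still give matching steps with a more different group at the same place, such as an amine or a carboxylic acid on the saturated chain carbon bound to an aromatic carbon.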